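Chain length between core and phenoxy group in the series

The source may report more compounds than this note shows. Statements on the series, on what has been measured and on what is new or still open speak of the compounds shown alone.

Two compounds of the shared core have been run in a functional assay on CHO cells for agonist activity at prostaglandin E2 receptor EP1 subtype (Homo sapiens), read by fluorescence and calcium flux; a lower number here means that less compound is needed, a higher number that more compound is needed for the effect. Compound 1, `O=C(O)c1csc([C@H]2CC[C@@H]3[C@@H](COc4ccccc4)[C@H](O)C[C@@H]3O2)n1`, carries a phenoxy group directly on the chain carbon attached to the saturated ring. In this assay compound 1 gives > 10000 nM, which is a limit of the assay and not a number. Compound 1 therefore stands at the limit of > 10000 nM in this assay, at which 1 of the 2 values shown sits. Compound 2, `O=C(O)c1csc([C@H]2CC[C@@H]3[C@@H](/C=C/CCOc4ccccc4)[C@H](O)C[C@@H]3O2)n1`, carries the phenoxy group on a longer unsaturated chain, and in this assay compound 2 gives 160 nM.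

The next compound, compound 3, `O=C(O)c1csc([C@H]2CC[C@@H]3[C@@H](CCOc4ccccc4)[C@H](O)C[C@@H]3O2)n1`, differs from compound 1 by phenoxymethyl in place of phenoxy on a saturated chain carbon bound to a saturated ring carbon; cut one bond further out, the change reads phenoxymethyl to 2-phenoxyethyl. The expected step from compound 1 to compound 3 is an at least 6.6-fold lower number from compound 1 to compound 3 (0.82 log units; beyond the scatter), a gain in potency well beyond the scatter, though compound 1 offers only a limit as the starting point. Compound 3 is expected to give 1500 nM, within a range of 300 nM to 8000 nM, since the still longer chain of compound 2 gives 160 nM in this assay.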

Compound 3, half-maximal effective concentration: 97 nM
Beside the measured number, compound 3's estimate is 15-fold (1.19 log units) above it; the measured number lies below the stated range.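

In this assay, the change from phenoxymethyl to 2-phenoxyethyl on a saturated chain carbon bound to a saturated ring carbon gives an at least 100-fold lower number from compound 1 to compound 3 (2.01 log units; beyond the scatter), so the length of this chain has a large bearing on the read-out. Compound 3 also shows that a fully saturated chain can give a measured number, 97 nM, whereas until now only the longer unsaturated chain of compound 2 had done so. The step is a bound and not an exact size, because compound 1 gives a limit of the assay and not a number: the limit of > 10000 nM in this assay, at which 1 of the 3 values shown sits.

As far as these compounds go, it remains open how the read-out changes with a longer saturated chain such as 3-phenoxypropyl or 4-phenoxybutyl, and whether the ether oxygen matters, which a plain carbon chain ending in phenyl would test. Also open, from the compounds shown here alone, is whether the chain effect holds when a primary amide takes the place of the carboxylic acid on the shared core, or when a substituent such as fluorine is placed on the phenyl ring.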